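The source may report more compounds than this note shows. Statements on the series, on what has been measured and on what is new or still open speak of the compounds shown alone.

Measured so far in a functional assay on Vero cells (Chlorocebus sabaeus) for inhibition; a higher number here means a weaker inhibitor, a lower number a stronger inhibitor:
- compound 1 `COc1cc(/C=C/C(=O)c2cccc(NC(=O)c3cccs3)c2)ccc1O`: 3.98 ug/mL
- compound 2 `COc1cc(/C=C/C(=O)c2cccc(NC(=O)C(C)C)c2)ccc1O`: 3.47 ug/mL
- compound 3 `CCOC(=O)C(=O)Nc1cccc(C(=O)/C=C/c2ccc(O)c(OC)c2)c1`: this result is a limit of the assay, > 50 ug/mL

Compound 1 holds the highest of the two numbers in this assay; the nearest is compound 2, with a 1.1-fold lower number from compound 1 to compound 2 (0.06 log units; within the scatter). Compound 3 sits at the limit of > 50 ug/mL in this assay, at which 1 of the 3 values shown sits, and gives no number.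

Compound 4 `COc1cc(/C=C/C(=O)c2cccc(NC(C)=O)c2)ccc1O` is not yet measured. It differs from compound 1 in one place: methyl in place of thiophen-2-yl on a carbonyl carbon.

Going by the values given here, two measured steps bear on this change. Swapping in a plain alkyl group gave a 1.1-fold lower number from compound 1 to compound 2 (0.06 log units; within the scatter), whereas swapping in an ester-bearing group gave an at least 12-fold higher number from compound 1 to compound 3 (1.09 log units; beyond the scatter) and, from the alkyl compound, an at least 14-fold higher number from compound 2 to compound 3 (1.15 log units; beyond the scatter). Methyl is the shorter alkyl counterpart of the isopropyl of compound 2, so the step expected in this assay is a 1.3-fold higher number from compound 1 to compound 4 (0.10 log units; within the scatter), that is, nothing beyond the scatter.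

Compound 4 is therefore estimated at 5 ug/mL in this assay, with a range from 2 ug/mL to 13 ug/mL.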

Compound 4, half-maximal inhibitory concentration: 14.5 ug/mL
The estimate for compound 4 lay 2.9-fold (0.46 log units) below the measured number; the whole stated range lies below it.
By their numbers in this assay, from the lowest: compounds 2 and 1 (each within the scatter of the next); then compound 4. At a limit, above all of these: compound 3.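

In this assay, the group on this carbonyl carbon matters even among plain alkyl groups: methyl in place of thiophen-2-yl gives a 3.6-fold higher number from compound 1 to compound 4 (0.56 log units; beyond the scatter), and methyl in place of isopropyl gives a 4.2-fold higher number from compound 2 to compound 4 (0.62 log units; beyond the scatter). The equivalence of isopropyl and thiophen-2-yl therefore does not extend to methyl, and compounds 1 and 2 alone gave no sign of this. Methyl in place of ethoxycarbonyl gives an at least 3.4-fold lower number from compound 3 to compound 4 (0.53 log units; beyond the scatter), which places compound 4 at an intermediate level, and this step rests on a limit of the assay for compound 3: the limit of > 50 ug/mL in this assay, at which 1 of the 4 values shown sits.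

On these data alone, it remains open whether an ethyl group or a longer chain on this carbonyl carbon would track compound 4 or compound 2. The effect of an amine or a carboxylic acid at this place is also unresolved.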